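This account rests on a few compounds, and the source may have more. Where it says the series, first, only, none or still open, it means among the compounds named here.

Compounds measured in a functional assay on MDA-MB-231 cells (Homo sapiens) for antiproliferative activity, read by MTT assay, with a stated time of 24 h; on this read-out higher numbers stand for weaker inhibition and lower numbers for stronger inhibition:

compound 1, `COc1ccc(-c2cc(/C=C/C(=O)c3cc(OC)c(OC)c(OC)c3)nc3cc(-c4ccccc4)nn23)cc1OC`, 4700 nM
compound 2, `COc1ccc(-c2cc(/C=C/C(=O)c3ccc(C)c(C)c3)nc3cc(-c4ccccc4)nn23)cc1OC`, 11500 nM
compound 3, `COc1ccc(C(=O)/C=C/c2cc(-c3ccc(OC)c(OC)c3)n3nc(-c4ccccc4)cc3n2)cc1OC`, 2600 nM

Among these three numbers compound 3 gives the lowest; the gap to compound 1 lies within the scatter, as a 1.8-fold lower number from compound 1 to compound 3 (0.26 log units; within the scatter) shows, while the gap to compound 2 lies beyond it, as a 4.4-fold lower number from compound 2 to compound 3 (0.65 log units; beyond the scatter) shows. Compound 4, `COc1ccc(-c2cc(/C=C/C(=O)c3ccc(Cl)cc3)nc3cc(-c4ccccc4)nn23)cc1OC`, is not yet measured. The change from compound 3 to compound 4 is 4-chlorophenyl in place of 3,4-dimethoxyphenyl on a carbonyl carbon.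

Among the compounds with values here, two measured steps concern the same carbonyl-bound ring. The step of a 2.4-fold higher number from compound 1 to compound 2 (0.39 log units; beyond the scatter) and the step of a 4.4-fold lower number from compound 2 to compound 3 (0.65 log units; beyond the scatter) both pair a ring without methoxy groups with a weaker number, so swapping the 3,4-dimethoxyphenyl ring of compound 3 for a 4-chlorophenyl ring is expected to raise the number in this assay, by a modest amount, as a 3.1-fold higher number from compound 3 to compound 4 (0.49 log units; beyond the scatter). Compound 4 is therefore estimated to give about 8000 nM, with a range from 3000 nM to 25000 nM.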

Compound 4, half-maximal inhibitory concentration: 17100 nM
Estimate against measurement, compound 4: 2.1-fold (0.33 log units) below, within the range that was stated.
By their numbers in this assay, from the lowest: compounds 3 and 1 (each within the scatter of the next); then compounds 2 and 4 (each within the scatter of the next).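

In this assay, this step (a 6.6-fold higher number from compound 3 to compound 4 (0.82 log units; beyond the scatter)) is the largest yet seen on changing the ring on the carbonyl carbon, and it shows that a 4-chlorophenyl ring gives up much of what the 3,4-dimethoxyphenyl ring provides. The 4-chlorophenyl ring cannot be told apart from the 3,4-dimethylphenyl ring (a 1.5-fold higher number from compound 2 to compound 4 (0.17 log units; within the scatter)), and the gap to the 3,4,5-trimethoxyphenyl ring also lies beyond the scatter (a 3.6-fold higher number from compound 1 to compound 4 (0.56 log units; beyond the scatter)), so among these four compounds both rings with methoxy groups give lower numbers than both rings without them, with no compound going against this. No measurement here accounts for that split.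

Still open, going by these compounds, is whether a single methoxy group on this ring would be enough to keep the lower numbers. On these data alone, it is also open where an unsubstituted phenyl ring, or a phenyl ring carrying an amine or a carboxylic acid, would fall.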